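The compounds below may be only part of what the source reports. "The series", "measured", "known", "first", "only" and "open" are said of these compounds alone.

The measured compounds:
compound 1, `COc1ccc(/C=C/C(=O)c2ccc(NC(=O)C(C)O[N+](=O)[O-])cc2)cc1`, which in a functional assay on the whole organism (strain albino) for inhibition, with Rattus norvegicus as the target, read by paw edema, with stated times of 30 min and 2 h, at a dose of 100 mg/kg by the oral route (on this read-out higher numbers stand for more inhibition at the one dose given (going by the name of the read-out) and lower numbers for less inhibition), gives 46%;
compound 2, `CC(O[N+](=O)[O-])C(=O)Nc1ccc(C(=O)/C=C/c2ccco2)cc1`, which in this assay gives 48%;
compound 3, `COc1ccc(/C=C/C(=O)c2ccc(NC(=O)COCc3c(-c4ccccc4)no[n+]3[O-])cc2)cc1`, which in this assay gives 42%.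

Compounds 1 and 2 differ in one place only: furan-2-yl in place of 4-methoxyphenyl on a double-bonded chain carbon bound to a double-bonded chain carbon. This change made a number 2 percentage points higher from compound 1 to compound 2 (within the scatter), so the two compounds cannot be told apart on this read-out. Compound 3 carries a core that differs from that of compound 1 in more than one place, and the difference between the two cores is not broken down here. Its value and that of compound 1 lie within the scatter of each other, as do its value and that of compound 2.

Compound 4, `O=C(COCc1c(-c2ccccc2)no[n+]1[O-])Nc1ccc(C(=O)/C=C/c2ccco2)cc1`, has not been measured yet. It stands to compound 3 exactly as compound 2 stands to compound 1: furan-2-yl in place of 4-methoxyphenyl on a double-bonded chain carbon bound to a double-bonded chain carbon. Since the same change earlier gave a number 2 percentage points higher from compound 1 to compound 2 (within the scatter), an equally small step is expected here as well: a number 2 percentage points higher from compound 3 to compound 4 (within the scatter). The estimated value for compound 4 in this assay is therefore 44%, expected to fall between 34% and 54%.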

Compound 4, a percentage reported as inhibition, in the whole organism at one dose (the size of the read-out at that dose, not a potency): 45%
Compound 4: the middle estimate sits 1 percentage points below what was measured; the measured number falls inside the stated range.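

In this assay, putting furan-2-yl in place of 4-methoxyphenyl gave a number 3 percentage points higher from compound 3 to compound 4 (within the scatter), and this step agrees with the one seen earlier on the other core: the same change on two cores in this assay, a number 2 percentage points higher (within the scatter) from compound 1 to compound 2 and a number 3 percentage points higher (within the scatter) from compound 3 to compound 4, 1 percentage points apart, within the scatter of two such steps On both cores, then, the change leaves the read-out within its usual scatter, so in these four compounds the small size of the step carries over from one core to the other. Going by these compounds alone, this does not show that the two groups are interchangeable in general: the evidence is only two cores and one read-out at a single dose, which is not a potency, and a step this small cannot reveal a real but modest effect of the change.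

The compounds shown leave open whether a group of a different kind, such as an amine or a carboxylic acid, on a double-bonded chain carbon bound to a double-bonded chain carbon would move the number beyond the scatter. They also leave open whether such a step would then carry over between the two cores.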